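The compounds below may be only part of what the source reports. "The series", "measured", "known", "first", "only" and "open" are said of these compounds alone.

Compound 1 `CCCn1c(=O)c2nc(-c3cnn(Cc4cccc(C)c4)c3)[nH]c2n(CCC)c1=O` gives the lowest number of the three measured compounds in an assay on CHO cells for displacement of a labelled ligand from adenosine receptor A1 (Homo sapiens) (a higher number here means a weaker inhibitor, a lower number a stronger inhibitor), at 48 nM. Compound 2 `CCCCn1c(=O)c2nc(-c3cnn(Cc4ccccc4)c3)[nH]c2n(CCCC)c1=O` gives 1400 nM in this assay, and compound 3 `CC(C)Cn1c(=O)c2nc(-c3cnn(Cc4cccc(C(F)(F)F)c4)c3)[nH]c2n(CC(C)C)c1=O` gives 3100 nM; both values lie beyond the scatter from that of compound 1. Compound 4 `CCCn1c(=O)c2nc(-c3cnn(Cc4cc(C(F)(F)F)ccc4Cl)c3)[nH]c2n(CCC)c1=O` is not yet measured. It differs from compound 1 by 2-chloro-5-(trifluoromethyl)phenyl in place of 3-methylphenyl on a saturated chain carbon bound to an aromatic nitrogen. No single change of this kind has been measured among the three compounds, and compounds 2 and 3 differ from compound 1 in more than one place. On the measured values of compounds 2 and 3 alone, compound 4 is expected to give a weaker result than compound 1, with a step of a 6.3-fold higher number from compound 1 to compound 4 (0.80 log units; beyond the scatter) beyond the scatter. Compound 4 is accordingly estimated at 300 nM in this assay, in a range from 60 nM to 1500 nM.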

Compound 4, inhibition constant: 1200 nM
Estimate against measurement, compound 4: 4.0-fold (0.60 log units) below, and the stated range covers the measured number.
By their numbers in this assay, from the lowest: compound 1; then compounds 4 and 2 (each within the scatter of the next); then compound 3.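

With the rest of compound 1 kept, 2-chloro-5-(trifluoromethyl)phenyl in place of 3-methylphenyl on a saturated chain carbon bound to an aromatic nitrogen brings a 25-fold higher number from compound 1 to compound 4 (1.40 log units; beyond the scatter) in this assay. For the compounds shown here, this shows that a change at this position alone can produce a large step, which the earlier compounds, each differing from compound 1 in more than one place, could not show. No measurement given here accounts for this step. As far as these compounds go, it remains open how much of the step belongs to the chlorine and how much to the trifluoromethyl, and how an amine or a carboxylic acid on this phenyl ring would read in this assay.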